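Ethyl to Isopropyl on a Weak Compound

A few compounds are considered here, and "the series" means these few. Any claim that something is new, unique, unknown or untested is made for them only; others in the source may bear on it.

Measured in a functional assay on A2780 cells (Homo sapiens) for antiproliferative activity, read by MTT assay, with a stated time of 48 h; a lower number here means a stronger inhibitor, a higher number a weaker inhibitor:
- compound 1 `COc1ccc(-c2cc3c(cn2)n(C)c(=O)n3-c2cc(OC)c(OC)c(OC)c2)cc1O`: 1720 nM
- compound 2 `CCn1c(=O)n(-c2cc(OC)c(OC)c(OC)c2)c2cc(-c3ccc(OC)c(O)c3)ncc21`: > 20000 nM

For compound 2 the figure > 20000 nM is a limit of the assay, not a number. Compound 3 `COc1ccc(-c2cc3c(cn2)n(C(C)C)c(=O)n3-c2cc(OC)c(OC)c(OC)c2)cc1O` changes one group of compound 2, ethyl to isopropyl: methyl in place of hydrogen on a saturated chain carbon bound to an aromatic nitrogen and a saturated chain carbon. Among the measured compounds shown here, the one measured step that bears on this also put a methyl in place of a hydrogen on a chain carbon bound to an aromatic nitrogen. It gave an at least 11-fold higher number from compound 1 to compound 2 (1.06 log units; beyond the scatter). For the measured compounds named here, with only this step to go on, a further rise in the number is expected, and compound 3 may well reach the limit too. The expected step is a step that the limit leaves unreadable from compound 2 to compound 3. For compound 3 the estimated value is 25000 nM, with an expected range of 8000 nM to 80000 nM.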

Compound 3, half-maximal inhibitory concentration: 3160 nM
The estimate for compound 3 lay 7.9-fold (0.90 log units) above the measured number; measured number outside the range, below it.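

In this assay the group on this nitrogen does not weaken the compounds in step with its size: ethyl to isopropyl gives an at least 6.3-fold lower number from compound 2 to compound 3 (0.80 log units; beyond the scatter) and brings back measurable activity. Isopropyl in place of methyl gives a 1.8-fold higher number from compound 1 to compound 3 (0.26 log units; within the scatter) and so leaves compound 3 and compound 1 indistinguishable, which makes ethyl the only one of the three groups that stands apart. The figure for compound 2 is a limit and not a number: the limit of > 20000 nM in this assay, at which 1 of the 3 values shown sits.

Three compounds cannot tell whether the result for ethyl reflects something particular to that group or is a single odd point in the series. As far as these compounds go, how a longer propyl chain or a cyclopropyl ring on this nitrogen would behave remains open.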